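A Dichlorophenyl Swap on the Carbonyl Carbon

A few compounds are considered here, and "the series" means these few. Any claim that something is new, unique, unknown or untested is made for them only; others in the source may bear on it.

Compound 1 `COc1cc(-c2cc(/C=C/C(=O)c3ccc(N)cc3)[nH]n2)cc(OC)c1OC`: 108%
Compound 2 `COc1ccc(-c2cc(/C=C/C(=O)c3ccc(OC)c(OC)c3)[nH]n2)cc1`: 91%

In a functional assay on IGROV-1 cells (Homo sapiens) for cytotoxicity, read by sulforhodamine B assay, with a stated time of 48 h, tested at 0.1 uM (a lower number here means a stronger effect, a higher number a weaker effect of the compound at the concentration tested), compound 1 gives 108%, the higher of the two numbers; compound 2 gives 91%, a gap beyond the usual scatter. Compound 3 `COc1cc(-c2cc(/C=C/C(=O)c3ccc(Cl)c(Cl)c3)[nH]n2)cc(OC)c1OC` differs from compound 1 in one place: 3,4-dichlorophenyl in place of 4-aminophenyl on a carbonyl carbon. Among the measured compounds shown here, no measured pair shows a change of this kind, so its effect is open. Because compound 1 reads 108%, a weak effect, compound 3 is expected to remain near that level, with a step of a number 8 percentage points lower from compound 1 to compound 3 (within the scatter) expected to stay within the scatter. Compound 3 is estimated at 100%, ranging from 82% to 115%.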

Compound 3, a percentage reported as activity, at one concentration (the size of the read-out at that concentration, not a potency): 98%
Beside the measured number, compound 3's estimate is 2 percentage points above it; the range from low to high includes it.
By their numbers in this assay, from the lowest: compounds 2, 3 and 1 (each within the scatter of the next, the first and the last beyond it).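

On the carbonyl carbon, 3,4-dichlorophenyl in place of 4-aminophenyl gives a number 10 percentage points lower from compound 1 to compound 3 (within the scatter) in this assay, the first one-place change seen at this position. Losing the hydrogen-bond donor and acceptor counted on 4-aminophenyl and gaining two chlorine atoms therefore does not separate the two compounds at this single concentration. On these data alone, whether a 4-hydroxyphenyl or a carboxylic acid on this carbon would move the read-out stays open. No measurement available here accounts for the size of this step.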